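A few compounds are considered here, and "the series" means these few. Any claim that something is new, unique, unknown or untested is made for them only; others in the source may bear on it.

For the measured compounds named here, in a functional assay on HCT-116 cells (Homo sapiens) for antiproliferative activity, read by MTT assay, with a stated time of 48 h (a lower number here means a stronger inhibitor, a higher number a weaker inhibitor), compound 2 `CCCCCCCC(CCO)n1cnc2c(Cl)ncnc21` gives 4160 nM, the only actual number so far. Compound 1 `CCCCCC(CCO)n1cnc2c(Cl)ncnc21` reaches only a limit, > 50000 nM. Compound 3 `CCCCCCCCC(CCO)n1cnc2c(Cl)ncnc21` differs from compound 2 by methyl in place of hydrogen on a saturated chain carbon, eight bonds along the chain from an aromatic nitrogen, which lengthens the same chain. Going by the values given here, one measured step bears on this: the large at least 12-fold lower number from compound 1 to compound 2 (1.07 log units; beyond the scatter), itself a limit-based step, in which ethyl entered the chain. Here only methyl enters, so a smaller move towards a lower number is expected in this assay. The estimated change is a 1.7-fold lower number from compound 2 to compound 3 (0.22 log units; within the scatter). For compound 3 the expected value is 2500 nM, within an estimated range of 900 nM to 7000 nM.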

Compound 3, half-maximal inhibitory concentration: 1650 nM
The estimate for compound 3 lay 1.5-fold (0.18 log units) above the measured number; low and high end bracket the measured number.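

In this assay, for the compounds shown here, methyl at this place on the chain gives a 2.5-fold lower number from compound 2 to compound 3 (0.40 log units; beyond the scatter), the first step here between two actual numbers, so the lengthening still pays beyond the point compound 2 had reached. Across the three compounds the number falls with each lengthening, with none going against this, and the full change is an at least 30-fold lower number from compound 1 to compound 3 (1.48 log units; beyond the scatter). Compound 1 holds only a limit, so that full change is a bound and not a size: the limit of > 50000 nM in this assay, at which 1 of the 3 values shown sits.

As far as these compounds go, whether a longer chain would lower the number further remains open. So does the effect of an amine or a carboxylic acid on the chain.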